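This account rests on a few compounds, and the source may have more. Where it says the series, first, only, none or still open, it means among the compounds named here.

Compound 1 `COc1cc(C)cc(-c2c(-c3ccnc(-c4ccc(C(C)=O)cc4)c3)cnn2CC#N)c1` carries an acetyl group. In a functional assay on K562 cells (Homo sapiens) for cytotoxicity, read by sulforhodamine B assay, with a stated time of 48 h, tested at 0.001 uM (a higher number here means a weaker effect of the compound at the concentration tested, a lower number a stronger effect), compound 1 gives 81%. Compound 2 `COc1cc(C)cc(-c2nn(CC#N)cc2-c2ccc(-c3cccc(C(C)=O)c3)nc2)c1` gives 82% in this assay, a number within the scatter of that of compound 1, so the two cannot be told apart. Compound 3 `Cc1cc(O)cc(-c2nn(CC#N)cc2-c2ccnc(-c3ccc(Oc4ccccc4)cc3)c2)c1` gives 63% in this assay, a number beyond the scatter below that of compound 1, a clearly stronger effect at this concentration. Compound 4 `COc1cc(C)cc(-c2c(-c3ccnc(-c4ccc(N(C)C)cc4)c3)cnn2CC#N)c1` is not yet measured; it differs from compound 1 by dimethylamino in place of acetyl on an aromatic carbon. Within the data shown here, no measured pair shows this change, so nothing among the measured compounds points in either direction. The step of a number 1 percentage points lower from compound 1 to compound 4 (within the scatter) is expected to stay within the scatter. Compound 4 is therefore estimated at 80%, in a range from 65% to 95%.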

Compound 4, a percentage reported as activity, at one concentration (the size of the read-out at that concentration, not a potency): 104%
Compound 4: the middle estimate sits 24 percentage points below what was measured, outside the stated range (above it).
By their numbers in this assay, from the lowest: compound 3; then compounds 1 and 2 (each within the scatter of the next); then compound 4.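

The position para to a large group on this phenyl ring is not indifferent to what it carries: in this assay, dimethylamino in place of acetyl gives a number 23 percentage points higher from compound 1 to compound 4 (beyond the scatter), a weaker effect at the concentration tested. The change matters even though the two groups match in heavy atoms and in hydrogen-bond donors and acceptors as counted. Nothing available explains this step.

The compounds shown leave open how a primary amine, a carboxylic acid or a longer chain would read at this position. They also leave open whether the same change would give a similar step on the core of compound 3.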